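This account rests on a few compounds, and the source may have more. Where it says the series, first, only, none or still open, it means among the compounds named here.

Going by the values given here, in a toxicity assay on MT4 cells (Homo sapiens) for cytotoxicity, read by MTT assay, with a stated time of 5 days (a lower number here means that less compound is tolerated, a higher number that more compound is tolerated), three compounds that share one core and differ in a single aromatic group have numbers so far. Compound 1 `Cc1cc(-c2ccco2)cc(C)c1Nc1ccnc(Nc2ccc(C#N)cc2)n1`, carrying furan-2-yl, gives 1700 nM. Compound 2 `Cc1cc(-c2cncnc2)cc(C)c1Nc1ccnc(Nc2ccc(C#N)cc2)n1`, carrying pyrimidin-5-yl, gives 6800 nM. Compound 3 `Cc1cc(-c2ccnc(C(F)(F)F)c2)cc(C)c1Nc1ccnc(Nc2ccc(C#N)cc2)n1`, carrying 2-(trifluoromethyl)pyridin-4-yl, gives 6100 nM, which puts it at the upper end of these three numbers.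

Compound 4 `Cc1cc(-c2cc(C)c(Nc3ccnc(Nc4ccc(C#N)cc4)n3)c(C)c2)cc(C)n1` has 2,6-dimethylpyridin-4-yl in place of 2-(trifluoromethyl)pyridin-4-yl on an aromatic carbon.

Two steps away from furan-2-yl were modest, a 4.0-fold higher number from compound 1 to compound 2 (0.60 log units; beyond the scatter) and a 3.6-fold higher number from compound 1 to compound 3 (0.55 log units; beyond the scatter). The closer precedent is the exchange of one six-membered aromatic group for another, a 1.1-fold lower number from compound 2 to compound 3 (0.05 log units; within the scatter). Among the compounds with values here, that is a single example, and no measured compound carries the methyl groups of the new pyridine. Even so, it suggests no step beyond the scatter in this assay. The expected change is a 1.4-fold lower number from compound 3 to compound 4 (0.13 log units; within the scatter). Compound 4 is estimated at about 4500 nM, with an expected range of 1700 nM to 12000 nM.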

Compound 4, half-maximal cytotoxic concentration: 2300 nM
The estimate for compound 4 lay 2.0-fold (0.29 log units) above the measured number, and the stated range covers the measured number.
By their numbers in this assay, from the lowest: compounds 1 and 4 (each within the scatter of the next); then compounds 3 and 2 (each within the scatter of the next).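

In this assay, swapping one six-membered aromatic group for another at this position is not always neutral, as shown by a 2.7-fold lower number from compound 3 to compound 4 (0.42 log units; beyond the scatter) and by a 3.0-fold lower number from compound 2 to compound 4 (0.47 log units; beyond the scatter), even though the swap between the pyrimidin-5-yl and 2-(trifluoromethyl)pyridin-4-yl groups had changed nothing beyond the scatter. Ring size alone therefore does not sort these numbers: compound 4 goes against such a pattern, with a 1.4-fold higher number from compound 1 to compound 4 (0.13 log units; within the scatter) placing this six-membered group level with the five-membered furan-2-yl. No measured evidence is available to explain this difference.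

The compounds shown cannot separate the arrival of the two methyl groups from the departure of the trifluoromethyl group, a question that pyridin-4-yl with no substituent or with one methyl group could address. Going by these compounds, how an amine or a carboxylic acid on this ring would behave in this assay also remains open.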